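The source may hold more compounds than are shown below. What is called first, only, known or untested is meant among the compounds shown, and "the series" means these compounds.

Measured so far in a functional assay on SW-620 cells (Homo sapiens) for inhibition, read by MTT assay, with a stated time of 72 h; a higher number here means a weaker inhibitor, a lower number a stronger inhibitor:
Compound 1 `COc1cc(NC(C)CCCNC(=O)NNC(=O)Nc2ccc(F)cc2)c2ncccc2c1`: > 100000 nM, a limit.
Compound 2 `COc1cc(NC(C)CCCNC(=O)NNC(=O)Nc2cccc(F)c2)c2ncccc2c1`: 9500 nM.

Among the compounds with values here, compound 2, at 9500 nM, holds the only actual number in this assay. The result for compound 1 is a limit. The next compound, compound 3 `COc1cc(NC(C)CCCNC(=O)NNC(=O)Nc2cccc(C(F)(F)F)c2)c2ncccc2c1`, has trifluoromethyl in place of fluoro on an aromatic carbon, meta to a large group: trifluoromethyl in place of fluoro on an aromatic carbon. Within the data shown here, only one measured step bears on this change: an at least 10-fold lower number from compound 1 to compound 2 (1.02 log units; beyond the scatter). That large step shows that this aryl group can matter, but it moved a fluoro group rather than replacing one, so it gives no direction for the new change. Only a modest shift is therefore expected, with a wide margin on either side. The expected step is a 1.4-fold lower number from compound 2 to compound 3 (0.13 log units; within the scatter). For compound 3 the estimated value is 7000 nM, with an expected range from 1800 nM to 30000 nM.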

Compound 3, half-maximal inhibitory concentration: 21000 nM
Compound 3: the middle estimate sits 3.0-fold (0.48 log units) below what was measured, and the stated range covers the measured number.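

Trifluoromethyl in place of fluoro gives a 2.2-fold higher number from compound 2 to compound 3 (0.34 log units; beyond the scatter) in this assay, so the group at this place on the ring affects the reading, not only where a fluoro group sits, as the earlier step had shown. Of the two groups compared here, fluoro gives the lower number, so this change brings no gain at this place. Against the 4-fluorophenyl compound the result is only a bound, an at least 4.7-fold lower number from compound 1 to compound 3 (0.67 log units; beyond the scatter), and that compound's reading is a limit: the limit of > 100000 nM in this assay, at which 1 of the 3 values shown sits.

Going by these compounds, it remains open whether a chlorine, a methoxy or a nitrile at the same place, or a phenyl ring with no such group, would give a lower number. The compounds shown also leave open how a shorter or longer chain would read with either aryl group.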